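The source may hold more compounds than are shown below. What is called first, only, known or untested is meant among the compounds shown, and "the series" means these compounds.

Measured compounds in a functional assay on PC-3 cells (Homo sapiens) for antiproliferative activity, read by MTT assay, with a stated time of 48 h; on this read-out higher numbers stand for weaker inhibition and lower numbers for stronger inhibition:
compound 1, `COc1cc(-c2nnc(SCC(=O)c3ccccc3)n2N)cc(OC)c1OC`: > 100000 nM, a limit of the assay.
compound 2, `COc1cc(-c2nnc(SCC(=O)c3ccc(F)cc3)n2N)cc(OC)c1OC`: > 100000 nM, a limit of the assay.
compound 3, `COc1cc(-c2nnc(SCC(=O)Nc3ccccc3F)n2N)cc(OC)c1OC`: 36700 nM.

Compound 3 thus holds the only number shown in this assay; the other two entries sit at the limit of > 100000 nM in this assay, at which 2 of the 3 values shown sit. Compound 4, `COc1cc(-c2nnc(SCC(=O)NCc3ccc(C)cc3)n2N)cc(OC)c1OC`, differs from compound 3 by 4-methylbenzyl in place of 2-fluorophenyl on an amide-type nitrogen. The measured steps that bear on it are an at least 2.7-fold lower number from compound 1 to compound 3 (0.43 log units; beyond the scatter) and an at least 2.7-fold lower number from compound 2 to compound 3 (0.43 log units; beyond the scatter), both exchanging the group on the carbonyl carbon for (2-fluorophenyl)amino; neither alters the substituent on the amide-type nitrogen, which is what changes here. Going by the values given here, with no measured step of this kind, the expectation for compound 4 is a 1.1-fold higher number from compound 3 to compound 4 (0.04 log units; within the scatter), a change not beyond the scatter. Compound 4 is therefore estimated at 40000 nM, within 15000 nM to 100000 nM.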

Compound 4, half-maximal inhibitory concentration: 92800 nM
Compound 4: the middle estimate sits 2.3-fold (0.37 log units) below what was measured; the measured number falls inside the stated range.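

In this assay, the substituent on the amide-type nitrogen has a readable effect: 4-methylbenzyl in place of 2-fluorophenyl gives a 2.5-fold higher number from compound 3 to compound 4 (0.40 log units; beyond the scatter). An amide on the carbonyl carbon is therefore not enough to hold the activity of compound 3. Against the aryl groups on the carbonyl carbon, the steps are only an at least 1.0-fold lower number from compound 1 to compound 4 (0.03 log units; that floor lies within the scatter) and an at least 1.0-fold lower number from compound 2 to compound 4 (0.03 log units; that floor lies within the scatter), and these stay open-ended because the values for compound 1 and compound 2 are limits: the limit of > 100000 nM in this assay, at which 2 of the 4 values shown sit.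

Going by these compounds, it remains open whether the step follows from the benzyl link, the methyl or the lost fluoro. Plain benzyl or 2-fluorobenzyl on that nitrogen would separate these.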